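A few compounds are considered here, and "the series" means these few. Any claim that something is new, unique, unknown or untested is made for them only; others in the source may bear on it.

Compound 1 `COc1cc(C#N)ccc1OCc1nnc(-c2ccc(F)cc2)o1` was tested in a functional assay on MCF7 cells (Homo sapiens) for cytotoxicity, read by MTT assay, with a stated time of 48 h (a lower number here means a stronger inhibitor, a higher number a weaker inhibitor), and compound 1 gave 10300 nM. Compound 2 `COc1cc(C#N)ccc1OCc1nnc(-c2ccc(Cl)cc2)o1` differs from it by chloro in place of fluoro on an aromatic carbon and gave 21500 nM, so that the change produced a 2.1-fold higher number from compound 1 to compound 2 (0.32 log units; beyond the scatter). Compound 3 `Fc1ccc(-c2nnc(COc3ccc(-c4nnco4)cc3)o2)cc1` shares the 4-fluorophenyl group with compound 1 but carries a different core; how the two cores differ is not broken down here. In this assay compound 3 gave 35600 nM, a number that sits within the scatter of compound 2 and beyond it from compound 1.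

Compound 4 `Clc1ccc(-c2nnc(COc3ccc(-c4nnco4)cc3)o2)cc1` has not yet been measured. It differs from compound 3 by chloro in place of fluoro on an aromatic carbon, the same change seen between compound 1 and compound 2, at the same place. Among the compounds with values here, the step is expected to be a 1.8-fold higher number from compound 3 to compound 4 (0.26 log units; within the scatter), resting on the single earlier example a 2.1-fold higher number from compound 1 to compound 2 (0.32 log units; beyond the scatter). Compound 4 is therefore estimated at 65000 nM, with a likely range from 32000 nM to 130000 nM.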

Compound 4, half-maximal inhibitory concentration: 45200 nM
Compound 4: the middle estimate sits 1.4-fold (0.16 log units) above what was measured; the range from low to high includes it.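

In this assay, chloro in place of fluoro gave a 1.3-fold higher number from compound 3 to compound 4 (0.10 log units; within the scatter), a step that does not stand out from the usual variation between repeated measurements. Set beside the earlier step, it shows no clear difference between the two cores: the same change on two cores in this assay, a 2.1-fold higher number (0.32 log units; beyond the scatter) from compound 1 to compound 2 and a 1.3-fold higher number (0.10 log units; within the scatter) from compound 3 to compound 4, 1.6-fold (0.22 log units) apart, within the scatter of two such steps. The change therefore carries across these two cores without a detectable difference in the size of its step, but two pairs, only one of them beyond the scatter, do not show that the step is truly the same on both cores or that it would hold on a third.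

Only fluoro and chloro appear at this place, so the compounds shown leave open what bromo, methoxy or an amine there would do on either core.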